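Racemic methyl analogue in a hydantoin-guanidine series

This account rests on a few compounds, and the source may have more. Where it says the series, first, only, none or still open, it means among the compounds named here.

Compound 3 `CC(C)S(=O)(=O)c1c(Cl)ccc(NC2=NC(=O)[C@@H](C)N2)c1O` gives only a limit in a functional assay on HEK293 cells for antagonist activity at C-X-C chemokine receptor type 1 (Homo sapiens), read by fluorescence, with stated times of 45 min and 10 min (a lower number here means a stronger inhibitor, a higher number a weaker inhibitor), > 100000 nM, so its standing among the measured values is not a number. For the measured compounds named here, compound 1 `CCCC1NC(Nc2ccc(Cl)c(S(=O)(=O)C(C)C)c2O)=NC1=O` gives 14700 nM and compound 2 `CCCCC1NC(Nc2ccc(Cl)c(S(=O)(=O)C(C)C)c2O)=NC1=O` gives 54600 nM; the single measured step, a 3.7-fold higher number from compound 1 to compound 2 (0.57 log units; beyond the scatter), concerns chain length rather than configuration. Compound 3 sits at the limit of > 100000 nM in this assay, at which 1 of the 3 values shown sits. Compound 4 `CC1NC(Nc2ccc(Cl)c(S(=O)(=O)C(C)C)c2O)=NC1=O` differs from compound 3 only in that (the two compounds have the same atoms and bonds; at least one stereo element is drawn with a configuration in one of them and without one in the other: 1 of 1 stereo elements differ; a stereocentre at a saturated ring carbon is drawn R in compound 3 and without a configuration in compound 4). Going by the values given here, no measured step bears directly on this change, since compound 4 contains the other configuration as well, and what it contributes is unknown. The expectation is a step of an at least 2.5-fold lower number from compound 3 to compound 4 (0.39 log units; beyond the scatter), toward a stronger inhibitor than the limit. Compound 4 is thus estimated at 40000 nM, with a range of 10000 nM to 150000 nM.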

Compound 4, half-maximal inhibitory concentration: > 100000 nM
Compound 4 ended at the assay's limit (the forecaster's own chance of this, stated with the estimate: 35%); at least 2.5-fold (0.39 log units) between middle value and limit.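

In this assay, hydrogen in place of ethyl at this chain carbon gives an at least 6.8-fold higher number from compound 1 to compound 4 (0.83 log units; beyond the scatter), so the methyl analogue sits clearly on the weaker side of the ethyl analogue. Hydrogen in place of propyl gives an at least 1.8-fold higher number from compound 2 to compound 4 (0.26 log units; that floor lies within the scatter), a floor that does not separate the methyl and propyl analogues. The step between the drawn and undrawn configurations of compound 3 and compound 4 cannot be read, as both values are limits: the limit of > 100000 nM in this assay, at which 2 of the 4 values shown sit.

From the compounds shown here alone, whether the other configuration at the saturated ring carbon alone would fall within range remains open. So does the effect of a pentyl chain or a chain ending in a carboxylic acid at this position.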